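Replacing Isopropyl with Cyclohexyl on the Amide Nitrogen

This account rests on a few compounds, and the source may have more. Where it says the series, first, only, none or still open, it means among the compounds named here.

Compound 1, `CNC(=O)c1cc(Oc2ccc(/C=C/c3ccncc3)cc2)ccn1`, in a functional assay on A549 cells (Homo sapiens) for antiproliferative activity, read by CCK-8 assay, with a stated time of 48 h; a lower number here means a stronger inhibitor, a higher number a weaker inhibitor: 13200 nM
Compound 2, `O=C(NCc1ccccc1)c1cc(Oc2ccc(/C=C/c3ccncc3)cc2)ccn1`: 17000 nM
Compound 3, `CC(C)NC(=O)c1cc(Oc2ccc(/C=C/c3ccncc3)cc2)ccn1`: 20600 nM

Compound 3 carries the highest of these three numbers, yet its steps to compound 2 and compound 1 are both within the scatter, so the three compounds cannot be separated. Compound 4, `O=C(NC1CCCCC1)c1cc(Oc2ccc(/C=C/c3ccncc3)cc2)ccn1`, differs from compound 3 in one place: cyclohexyl in place of isopropyl on an amide-type nitrogen. The earlier changes on the same amide nitrogen bear on this: a 1.6-fold higher number from compound 1 to compound 3 (0.19 log units; within the scatter), a 1.2-fold higher number from compound 2 to compound 3 (0.08 log units; within the scatter) and a 1.3-fold higher number from compound 1 to compound 2 (0.11 log units; within the scatter), none beyond the scatter. Because varying this group has so far given a 1.6-fold higher number from compound 1 to compound 3 (0.19 log units; within the scatter) and a 1.2-fold higher number from compound 2 to compound 3 (0.08 log units; within the scatter), compound 4 is expected to show no step beyond the scatter, that is a 1.0-fold lower number from compound 3 to compound 4 (0.01 log units; within the scatter). The estimate for compound 4 is 20000 nM, ranging from 8000 nM to 50000 nM.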

Compound 4, half-maximal inhibitory concentration: 16800 nM
Compound 4: middle estimate off by 1.2-fold (0.08 log units), on the high side; the range from low to high includes it.
By their numbers in this assay, from the lowest: compounds 1, 4, 2 and 3 (each within the scatter of the next).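

In this assay, a non-aromatic ring of six carbons on the amide nitrogen still gives no separable change, whichever of the earlier groups it replaces: a 1.2-fold lower number from compound 3 to compound 4 (0.09 log units; within the scatter), a 1.0-fold lower number from compound 2 to compound 4 (0.01 log units; within the scatter) and a 1.3-fold higher number from compound 1 to compound 4 (0.10 log units; within the scatter). The four groups seen on this nitrogen, methyl, isopropyl, benzyl and cyclohexyl, therefore cover a wider range of size and shape without any step beyond the scatter. Nothing available explains this flat result. As far as these compounds go, whether an amine or a carboxylic acid carried on this nitrogen would move the number beyond the scatter remains open.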